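Aryl urea series: permeability across a para substituent swap

This account rests on a few compounds, and the source may have more. Where it says the series, first, only, none or still open, it means among the compounds named here.

Compound 1 `CSc1ccc(NC(=O)Nc2cc(C)nc3ccccc23)cc1`: 473 10^-6 cm/s in an ADME assay for permeability, using PAMPA, at pH 7.4; on this read-out higher numbers stand for higher permeability and lower numbers for lower permeability
Compound 2 `Cc1cc(NC(=O)Nc2ccc(OC(F)(F)F)cc2)c2ccccc2n1`: 531 10^-6 cm/s in this assay
Compound 3 `CCc1ccc(NC(=O)Nc2cc(C)nc3ccccc23)cc1`: 535 10^-6 cm/s in this assay

The three compounds share one core and differ only in the group on the aromatic carbon of the phenyl urea. Compound 3 sits with the others: a 1.0-fold higher number from compound 2 to compound 3 (0.00 log units; within the scatter), and a 1.1-fold higher number from compound 1 to compound 3 (0.05 log units; within the scatter). The remaining pair behaves the same way, a 1.1-fold higher number from compound 1 to compound 2 (0.05 log units; within the scatter). Methylsulfanyl, trifluoromethoxy and ethyl at this position therefore give numbers that cannot be told apart in this assay.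

Compound 4 `Cc1cc(NC(=O)Nc2ccc(C(F)(F)F)cc2)c2ccccc2n1` is not yet measured. Its change from compound 3 is trifluoromethyl in place of ethyl on an aromatic carbon. For the measured compounds named here, no measured step carries trifluoromethyl, so no step speaks to it directly; the steps that bear on it are the three swaps at the same carbon, all within the scatter, including the move from ethyl to a fluorinated group, a 1.0-fold higher number from compound 2 to compound 3 (0.00 log units; within the scatter) in the reverse sense. Against that background no step beyond the scatter is expected in this assay for compound 4 in either direction.

For compound 4 the expected step in this assay is a 1.0-fold lower number from compound 3 to compound 4 (0.02 log units; within the scatter). For compound 4 the estimated value in this assay is 510 10^-6 cm/s, with a range from 340 10^-6 cm/s to 760 10^-6 cm/s.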

Compound 4, apparent permeability: 2 10^-6 cm/s
For compound 4 the middle estimate is 260-fold (2.41 log units) above the measured one; measured number outside the range, below it.
By their numbers in this assay, from the lowest: compound 4; then compounds 1, 2 and 3 (each within the scatter of the next).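

In this assay this aromatic carbon proves far less tolerant than the three earlier swaps suggested: trifluoromethyl in place of ethyl gives a 270-fold lower number from compound 3 to compound 4 (2.43 log units; beyond the scatter), and the same collapse appears against the other two groups, with a 270-fold lower number from compound 2 to compound 4 (2.42 log units; beyond the scatter) and a 240-fold lower number from compound 1 to compound 4 (2.37 log units; beyond the scatter). Fluorine on the substituent does not by itself mark the change, as compound 2, which carries trifluoromethoxy, stays within the scatter of compound 1 and compound 3, so among these four groups only trifluoromethyl stands apart. Nothing at hand explains so large a step from the exchange of one small group for another.

For the compounds shown here, compound 4 is the only compound here with trifluoromethyl, so it remains open whether this step is particular to that group or would recur at the same carbon with a nitrile, a chlorine atom, a methyl group or a longer chain. Also open, on these data alone, is whether trifluoromethyl gives a step of this size on any core other than the shared one.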